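Series notes: from compound 1 to compound 4

The source may hold more compounds than are shown below. What is called first, only, known or untested is meant among the compounds shown, and "the series" means these compounds.

Compound 1 `NC(=O)c1c(NC(=O)c2ccccc2Cl)sc2c1CCN(Cc1ccccc1Cl)C2` is the reference point. In a functional assay on HeLa cells (Homo sapiens) for antiproliferative activity, with a stated time of 24 h (a higher number here means a weaker inhibitor, a lower number a stronger inhibitor), compound 1 gives 27500 nM, the lowest of the two numbers in hand. Compound 3 `NC(=O)c1c(NC(=O)c2cccc([N+](=O)[O-])c2)sc2c1CCN(Cc1ccc(Cl)cc1Cl)C2` gives 33000 nM in this assay, a gap from compound 1 that stays within the usual scatter. Compound 2 `Cc1ccc(C(=O)Nc2sc3c(c2C(N)=O)CCN(Cc2ccc(Cl)cc2Cl)C3)cc1` reaches only > 50000 nM in this assay, a limit of the assay rather than a number. Among the compounds with values here, the one measured step, an at least 1.5-fold lower number from compound 2 to compound 3 (0.18 log units; that floor lies within the scatter), sits on a carbonyl carbon and its floor lies within the scatter; beyond that, the limit of > 50000 nM in this assay, at which 1 of the 3 values shown sits, is all the evidence there is.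

Compound 4 `Cc1ccccc1NC(=S)N1CCc2c(sc(NC(=O)c3ccccc3Cl)c2C(N)=O)C1` differs from compound 1 on the other side of the shared core: a group of 10 heavy atoms (8 carbon, 1 nitrogen, 1 sulfur; one six-membered aromatic ring of carbon only) in place of a group of 8 heavy atoms (7 carbon, 1 chlorine; one six-membered aromatic ring of carbon only), on an amine nitrogen in a ring. Within the data shown here, no measured step touches the amine nitrogen in the ring, so this change is uncharted. Among the measured compounds shown here, with the only comparison lying on the carbonyl side, no step beyond the scatter is expected in this assay, and the estimated step is a 1.1-fold higher number from compound 1 to compound 4 (0.04 log units; within the scatter). Compound 4 is expected to give about 30000 nM in this assay, within 8000 nM to 50000 nM, with a fair chance that only a limit is returned.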

Compound 4, half-maximal inhibitory concentration: > 50000 nM
Compound 4 ended at the assay's limit; the forecaster's own chance of this, stated with the estimate: 30%; middle value at least 1.6-fold (0.22 log units) away from the limit.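

The amine nitrogen in the ring now has its first measured step: an at least 1.8-fold higher number from compound 1 to compound 4 (0.25 log units; that floor lies within the scatter). The value of compound 4 is a limit of the assay and not a number, so the size of this step in this assay stays unread, and its floor does not clear the scatter. Replacing 2-chlorobenzyl with the group of 10 heavy atoms therefore gives no lower number, and compound 4 joins compound 2 at the limit: the limit of > 50000 nM in this assay, at which 2 of the 4 values shown sit.

What the compounds shown leave open is whether any other group on this nitrogen, such as a short chain ending in an amine or a carboxylic acid, gives a lower number than compound 1. Within the data shown here, the single change here also cannot separate the double bond outside aromatic rings from the hydrogen-bond donor that enters with it.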